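Exchanging the hydroxy of compound 3 for a dimethylcarbamoyl group

The compounds below may be only part of what the source reports. "The series", "measured", "known", "first", "only" and "open" are said of these compounds alone.

Of the compounds shown here, three have been measured in an assay on ileum with muscarinic acetylcholine receptor M3 (Cavia porcellus) as the target; on this read-out lower numbers stand for stronger inhibition and higher numbers for weaker inhibition. Compound 1 `Cc1nccn1CCCCC(C(N)=O)(c1ccccc1)c1ccccc1` gives 43.7 nM, compound 2 `Cc1nccn1CC(C)C(C(N)=O)(c1ccccc1)c1ccccc1` gives 2.89 nM, and compound 3 `Cc1nccn1CCC(O)(c1ccccc1)c1ccccc1` gives 16.7 nM. Compound 3 thus holds the second highest of the three numbers: it sits closest to compound 1, whose number is higher, and furthest from compound 2, whose number is lower, both gaps lying beyond the usual scatter. Compound 4 `Cc1nccn1CCC(C(=O)N(C)C)(c1ccccc1)c1ccccc1` has not yet been tested in this assay. It differs from compound 3 by dimethylcarbamoyl in place of hydroxy on a saturated chain carbon bound to two aromatic carbons and a saturated chain carbon. Among the compounds with values here, with no measured pair of this kind to lean on, a modest move toward a lower number is expected, as a 1.7-fold lower number from compound 3 to compound 4 (0.22 log units; within the scatter). Compound 4 is therefore estimated at 10 nM, within 3 nM to 35 nM.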

Compound 4, antagonist equilibrium constant: 258 nM
Compound 4: middle estimate off by 26-fold (1.41 log units), on the low side, and the stated range ends below it.
By their numbers in this assay, from the lowest: compound 2; then compound 3; then compound 1; then compound 4.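

In this assay, the saturated chain carbon bound to two aromatic carbons and a saturated chain carbon proves highly sensitive to the group it carries. Dimethylcarbamoyl in place of hydroxy gives a 15-fold higher number from compound 3 to compound 4 (1.19 log units; beyond the scatter) and so provides the first single-place comparison in this set, a large step toward weaker inhibition. The compounds shown leave open how a methoxy group, an amine or a carboxylic acid would behave at this same carbon on the core of compound 3. No measurement at hand says what lies behind the step.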